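Swapping a Nitrile Ring for a Fluoro-Methoxy Ring

The compounds below may be only part of what the source reports. "The series", "measured", "known", "first", "only" and "open" are said of these compounds alone.

Measured in a functional assay on HeLa cells (Homo sapiens) for inhibition, read by CCK-8 assay, with a stated time of 48 h; on this read-out higher numbers stand for weaker inhibition and lower numbers for stronger inhibition:

compound 1 `COc1cc(-c2ccnc3cc(-c4ccc(C)cc4)nn23)cc(OC)c1OC`: 21 nM
compound 2 `COc1cc(-c2ccnc3cc(-c4ccc(C)c(C)c4)nn23)cc(OC)c1OC`: 241 nM
compound 3 `COc1cc(-c2ccnc3cc(-c4cccc(C#N)c4)nn23)cc(OC)c1OC`: > 10000 nM, which is a limit of the assay and not a number

Compound 3 therefore stands at the weak end of the three, with its result known only as a limit (the limit of > 10000 nM in this assay, at which 1 of the 3 values shown sits). Both steps leading to it were large: an at least 470-fold higher number from compound 1 to compound 3 (2.67 log units; beyond the scatter) and an at least 41-fold higher number from compound 2 to compound 3 (1.61 log units; beyond the scatter). Compound 4 `COc1ccc(-c2cc3nccc(-c4cc(OC)c(OC)c(OC)c4)n3n2)cc1F` differs from compound 3 by 3-fluoro-4-methoxyphenyl in place of 3-cyanophenyl on an aromatic carbon. For the measured compounds named here, no measured step shows this exact change. The nearest guides are the two steps into compound 3, read backwards: removing the 3-cyanophenyl in favour of a methyl-bearing ring gave large gains in potency. Compound 4 carries a 3-fluoro-4-methoxyphenyl, a ring bearing two groups, as does the 3,4-dimethylphenyl of compound 2, so a large fall in number is expected, an at least 33-fold lower number from compound 3 to compound 4 (1.52 log units; beyond the scatter), with compound 2 rather than compound 1 as the closer reference. Compound 4 is estimated at 300 nM, within 50 nM to 3000 nM.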

Compound 4, half-maximal inhibitory concentration: 236 nM
For compound 4 the middle estimate is 1.3-fold (0.10 log units) above the measured one, and the stated range covers the measured number.
By their numbers in this assay, from the lowest: compound 1; then compounds 4 and 2 (each within the scatter of the next). At a limit, above all of these: compound 3.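

Compound 3 is known in this assay only as a limit of the assay and not as a number: the limit of > 10000 nM in this assay, at which 1 of the 4 values shown sits. Putting 3-fluoro-4-methoxyphenyl in place of 3-cyanophenyl gives an at least 42-fold lower number from compound 3 to compound 4 (1.62 log units; beyond the scatter), so strong activity at this position does not require a methyl-bearing ring. The 3-fluoro-4-methoxyphenyl and 3,4-dimethylphenyl rings cannot be told apart, with a 1.0-fold lower number from compound 2 to compound 4 (0.01 log units; within the scatter), while the 4-methylphenyl ring stays ahead of the 3-fluoro-4-methoxyphenyl ring, with an 11-fold higher number from compound 1 to compound 4 (1.05 log units; beyond the scatter).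

On these data alone, it remains open whether the fluorine, the methoxy or the two together account for the difference between compound 4 and compound 3. As far as these compounds go, how a phenyl ring bearing an amine or a carboxylic acid would behave at this position also remains open.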